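Swapping sec-Butyl for 2-Hydroxypropyl on an Inactive Core

The source may hold more compounds than are shown below. What is called first, only, known or untested is meant among the compounds shown, and "the series" means these compounds.

Compound 1 `CCC(C)n1cnc2ncnc(N)c21` and compound 2 `CC(C)Cn1cnc2c(N)ncnc21` share one core and differ only in the chain carried on the aromatic nitrogen. In an assay on CHO cells for displacement of a labelled ligand from adenosine receptor A3 (Homo sapiens) (a lower number here means a stronger inhibitor, a higher number a weaker inhibitor), compound 1 reaches only a limit, reported as > 100000 nM. In this assay compound 2 likewise reaches only a limit, reported as > 100000 nM. Both recorded values therefore sit at the limit of > 100000 nM in this assay, at which 2 of the 2 values shown sit, and nothing in these numbers separates the two compounds. Compound 3 `CC(O)Cn1cnc2ncnc(N)c21` is the compound yet to be tested; it carries 2-hydroxypropyl in place of sec-butyl on an aromatic nitrogen, that is, 2-hydroxypropyl in place of sec-butyl on an aromatic nitrogen. Among the measured compounds shown here, no measured pair shows what this change does. Because compound 1 gives only the limit > 100000 nM in this assay, compound 3 is expected to remain near that limit as well, at an estimated 100000 nM with a range from 30000 nM to 300000 nM. The expected step of a number no higher from compound 1 to compound 3 (the limit leaves the size open) thus amounts to nothing beyond the usual scatter.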

Compound 3, inhibition constant: > 100000 nM
Compound 3 gave a limit, no number (the forecaster's own chance of this, stated with the estimate: 80%); the middle value lies on the limit itself.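

Compound 3, like compound 1, gives only a limit and no number in this assay, so the step between them cannot be read: the limit of > 100000 nM in this assay, at which 3 of the 3 values shown sit. The compounds shown leave open whether any chain on the aromatic nitrogen of the shared core gives a measurable value in this assay.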